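Sulfonamide phenyl group: from phenyl to 3,5-dimethylphenyl

This account rests on a few compounds, and the source may have more. Where it says the series, first, only, none or still open, it means among the compounds named here.

In a functional assay on MCF7 cells (Homo sapiens) for antiproliferative activity, read by sulforhodamine B assay, with a stated time of 48 h (on this read-out lower numbers stand for stronger inhibition and higher numbers for weaker inhibition), compound 1 `Cc1cccc(NS(=O)(=O)c2ccc(N3CCNC3=O)cc2)c1` gives 190 nM, compound 2 `O=C1NCCN1c1ccc(S(=O)(=O)Nc2ccc(F)cc2)cc1` gives 690 nM and compound 3 `O=C1NCCN1c1ccc(S(=O)(=O)Nc2ccccc2)cc1` gives 470 nM. Two steps place compound 3: a 1.5-fold lower number from compound 2 to compound 3 (0.17 log units; within the scatter) and a 2.5-fold higher number from compound 1 to compound 3 (0.39 log units; beyond the scatter).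

Compound 4 `Cc1cc(C)cc(NS(=O)(=O)c2ccc(N3CCNC3=O)cc2)c1` carries 3,5-dimethylphenyl in place of phenyl on a sulfonamide nitrogen. Going by the values given here, the closest precedent is a 2.5-fold higher number from compound 1 to compound 3 (0.39 log units; beyond the scatter), where hydrogen replaces methyl on an aromatic carbon. Read in reverse, it points to a lower number for compound 4. The data do not show whether a further methyl adds to this, so a step of similar size is expected, beyond the scatter. The expected change is a 3.4-fold lower number from compound 3 to compound 4 (0.53 log units; beyond the scatter). For compound 4 the estimated value is 140 nM, with an expected range of 60 nM to 320 nM.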

Compound 4, half-maximal inhibitory concentration: 100 nM
The estimate for compound 4 lay 1.4-fold (0.15 log units) above the measured number; the measured number falls inside the stated range.
By their numbers in this assay, from the lowest: compounds 4 and 1 (each within the scatter of the next); then compounds 3 and 2 (each within the scatter of the next).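

Replacing phenyl with 3,5-dimethylphenyl on the sulfonamide nitrogen gives a 4.7-fold lower number from compound 3 to compound 4 (0.67 log units; beyond the scatter) as the step, and replacing 4-fluorophenyl with it gives a 6.9-fold lower number from compound 2 to compound 4 (0.84 log units; beyond the scatter) as the step, so this position accepts two methyl groups. The second methyl brings no separable gain, with a 1.9-fold lower number from compound 1 to compound 4 (0.28 log units; within the scatter) as the step from the single methyl. No measurement at hand accounts for these steps.

Still open, going by these compounds, is whether a methoxy group or chlorine in place of these methyl groups would match compound 4. An amine or a carboxylic acid on this ring is equally untested in the compounds shown.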